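The source may hold more compounds than are shown below. What is called first, only, known or untested is meant among the compounds shown, and "the series" means these compounds.

Working notes on the series. Among the measured compounds shown here, compound 2 `Cc1cccc2c1CCCC2c1c[nH]cn1` gives 191 nM in an assay on cell membranes for displacement of a labelled ligand from Adrenergic receptor alpha-1 (Rattus norvegicus) (on this read-out higher numbers stand for weaker inhibition and lower numbers for stronger inhibition), and compound 1 `COc1cccc2c1CCCC2c1c[nH]cn1` gives 243 nM in this assay; the only measured step here is a 1.3-fold lower number from compound 1 to compound 2 (0.10 log units; within the scatter). Compound 3 `Oc1cccc2c1CCCC2c1c[nH]cn1` differs from compound 2 by hydroxy in place of methyl on an aromatic carbon. For the measured compounds named here, only that one small step at the same aromatic carbon bears on this change, and no measured pair introduces a hydroxy, so the expectation rests on little. No step beyond the scatter is expected in this assay for compound 3. Compound 3 is estimated at 250 nM in this assay, with a range from 80 nM to 800 nM. For compound 3 this corresponds to an expected step of a 1.3-fold higher number from compound 2 to compound 3 (0.12 log units; within the scatter).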

Compound 3, inhibition constant: 126 nM
Beside the measured number, compound 3's estimate is 2.0-fold (0.30 log units) above it, within the range that was stated.
By their numbers in this assay, from the lowest: compounds 3, 2 and 1 (each within the scatter of the next).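

In this assay the change to hydroxy at this aromatic carbon gives a 1.5-fold lower number from compound 2 to compound 3 (0.18 log units; within the scatter) and hydrogen in place of methyl on the oxygen gives a 1.9-fold lower number from compound 1 to compound 3 (0.29 log units; within the scatter), so methyl, methoxy and hydroxy all lie within the scatter here. Entry of a hydrogen-bond donor at this carbon thus brings no step beyond the scatter. No measurement at hand accounts for this reading. Going by these compounds, whether an amine, a carboxylic acid or a longer chain at this carbon would also stay within the scatter remains open, as does how hydroxy reads elsewhere on the aromatic ring.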